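Triazole methyl removal in the series of compound 1

The source may hold more compounds than are shown below. What is called first, only, known or untested is meant among the compounds shown, and "the series" means these compounds.

Compound 1 `CCn1ncc2c(F)cc(-c3ccc(C(CC)(CC)c4nnc(C)[nH]4)c(=O)[nH]3)cc21` is the reference point. For the measured compounds named here, in a physicochemical assay for solubility, measured as kinetic solubility, at pH 2 (on this read-out lower numbers stand for lower solubility and higher numbers for higher solubility), compound 1 gives 33900 nM, and compound 2 `CC(C)C(/C=C1\CCNC1=O)c1ccc(-c2ccc3cccc(F)c3c2)[nH]c1=O` gives 23600 nM in the same assay; the two numbers lie within the scatter of each other, so compound 1 stands level with the only other measured compound. Going by the values given here, no single-point step between measured compounds is available. Compound 3 `CCn1ncc2c(F)cc(-c3ccc(C(CC)(CC)c4nnc[nH]4)c(=O)[nH]3)cc21` differs from compound 1 by hydrogen in place of methyl on an aromatic carbon. For compound 3 a step of a 1.2-fold higher number from compound 1 to compound 3 (0.07 log units; within the scatter) is expected, no larger than the usual scatter, if anything toward a slightly higher number. Compound 3 is therefore estimated at 40000 nM, within 20000 nM to 80000 nM.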

Compound 3, solubility: 39100 nM
Beside the measured number, compound 3's estimate is 1.0-fold (0.01 log units) above it, and the stated range covers the measured number.
By their numbers in this assay, from the lowest: compounds 2, 1 and 3 (each within the scatter of the next).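

In this assay, for the compounds shown here, going from 5-methyl-4H-1,2,4-triazol-3-yl to 4H-1,2,4-triazol-3-yl gives a 1.2-fold higher number from compound 1 to compound 3 (0.06 log units; within the scatter) as the first single-point step. On this aromatic carbon, between two ring nitrogen atoms, methyl and hydrogen therefore stand level on this read-out. No evidence on the origin of this result is available.

Open, as far as these compounds go, is whether another group at this carbon, such as a longer chain, an amine or a carboxylic acid, would give a step beyond the scatter. Also open, from the compounds shown here alone, is whether the same change would read alike on another core.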